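The compounds below may be only part of what the source reports. "The series", "measured", "known", "first", "only" and "open" are said of these compounds alone.

In a functional assay on HepG2 cells (Homo sapiens) for antiproliferative activity, read by MTT assay, with a stated time of 48 h (a higher number here means a weaker inhibitor, a lower number a stronger inhibitor), two compounds sharing one core have been measured. Compound 1 `COc1ccc(/C=C/c2cc(OC)cc(OC)c2/C=C/C(=O)c2ccc(Cl)cc2)cc1` gives 13.6 ug/mL. Compound 2 `COc1ccc(/C=C/c2cc(OC)cc(OC)c2/C=C/C(=O)c2ccc(C)c(C)c2)cc1` gives 0.2 ug/mL, the lower of the two numbers. Compound 3 `CCN(CC)c1ccc(C(=O)/C=C/c2c(/C=C/c3ccc(OC)cc3)cc(OC)cc2OC)cc1` differs from compound 2 at a single place, on a carbonyl carbon, where 4-(diethylamino)phenyl stands in place of 3,4-dimethylphenyl: 4-(diethylamino)phenyl in place of 3,4-dimethylphenyl on a carbonyl carbon. Within the data shown here, the only measured step bearing on this is a 68-fold lower number from compound 1 to compound 2 (1.83 log units; beyond the scatter), a large change beyond the scatter at that same place. Among the measured compounds shown here, it shows that replacing the group there can shift the number strongly, but no measured compound carries 4-(diethylamino)phenyl, so its direction here is uncertain. Since compound 2 sits at the low end with 0.2 ug/mL, a higher number is the more likely outcome, and the expected change is a 7.5-fold higher number from compound 2 to compound 3 (0.88 log units; beyond the scatter). For compound 3 the estimated value is 1.5 ug/mL, with an expected range of 0.2 ug/mL to 12 ug/mL.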

Compound 3, half-maximal inhibitory concentration: 6.3 ug/mL
For compound 3 the middle estimate is 4.2-fold (0.62 log units) below the measured one, within the range that was stated.
By their numbers in this assay, from the lowest: compound 2; then compound 3; then compound 1.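

In this assay, 4-(diethylamino)phenyl in place of 3,4-dimethylphenyl gives a 32-fold higher number from compound 2 to compound 3 (1.50 log units; beyond the scatter) on this same carbonyl carbon, a second large shift at this place and the first upward from the low end of the series. Diethylamino in place of chloro on an aromatic carbon gives only a 2.2-fold lower number from compound 1 to compound 3 (0.33 log units; beyond the scatter), a modest step, so among these three compounds the low number belongs to compound 2 alone. Nothing available here accounts for either shift.

As far as these compounds go, it remains open whether an unsubstituted phenyl or a phenyl carrying a single methyl would keep the low number of compound 2, or whether both methyl groups are required. A smaller amine such as dimethylamino, or an ether such as methoxy, also remains to be placed against diethylamino and chloro.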